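Cyclohexanecarboxamide to 4-chlorobenzamide on the thiadiazole amide

The source may report more compounds than this note shows. Statements on the series, on what has been measured and on what is new or still open speak of the compounds shown alone.

Measured compounds:
- compound 1, `O=C(Nc1nnc(-c2cccc(O)c2O)s1)C1CCCCC1`: 91600 nM
- compound 2, `O=C(Nc1nnc(-c2ccc(O)c(O)c2)s1)C1CCCCC1`: 34500 nM

In a functional assay on HeLa cells (Homo sapiens) for cytotoxicity, read by MTT assay, with a stated time of 72 h (on this read-out higher numbers stand for weaker inhibition and lower numbers for stronger inhibition), compound 1 gives 91600 nM, the highest of the two numbers; compound 2 gives 34500 nM, a lower number that lies beyond the scatter. Compound 3, `O=C(Nc1nnc(-c2cccc(O)c2O)s1)c1ccc(Cl)cc1`, is not yet measured. It differs from compound 1 by 4-chlorophenyl in place of cyclohexyl on a carbonyl carbon. Among the measured compounds shown here, no measured pair shows this change, so the size of its effect is unknown. The expectation for compound 3 is a step of a 1.3-fold lower number from compound 1 to compound 3 (0.12 log units; within the scatter) from compound 1, of no clear direction beyond the scatter. The estimate for compound 3 is 70000 nM, with a range from 20000 nM to 200000 nM.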

Compound 3, half-maximal inhibitory concentration: 13000 nM
Compound 3: middle estimate off by 5.4-fold (0.73 log units), on the high side, outside the stated range (below it).
By their numbers in this assay, from the lowest: compound 3; then compound 2; then compound 1.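

In this assay, the group on the carbonyl carbon matters: compound 1 and compound 2 share cyclohexyl and left this position unread, whereas 4-chlorophenyl in place of cyclohexyl gives a 7.0-fold lower number from compound 1 to compound 3 (0.85 log units; beyond the scatter). This rests on a single pair, on the core of compound 1. Nothing at hand gives a reason for the step.

The compounds shown do not separate the aromatic ring from its chlorine, which a plain phenyl or 4-methoxyphenyl would address. Going by these compounds, whether the step carries over to the core of compound 2 also remains open.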